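Changing the amine chain of compound 2

The source may hold more compounds than are shown below. What is called first, only, known or untested is meant among the compounds shown, and "the series" means these compounds.

Measured in a functional assay on HEK293 cells (Homo sapiens) for inhibition; a higher number here means a weaker inhibitor, a lower number a stronger inhibitor:
- compound 1 `CCCCCCCCS(=O)(=O)NCCCNCCCNCCCCNCCCN`: 816 nM
- compound 2 `CCCCCCCCS(=O)(=O)NCCCNCCCNCCCN`: 5560 nM
- compound 3 `CCCCCCCCCCCCS(=O)(=O)NCCCNCCCNCCCN`: 363 nM

Compound 2 (5560 nM) has the highest number of the three, and the numbers of the other two lie beyond the scatter from it. The compound still to be measured, compound 4 `CCCCCCCCS(=O)(=O)NCCCNC/C=C/CNCCCN`, keeps the sulfonyl end of compound 2 and alters its amine chain: a group of 8 heavy atoms (6 carbon, 2 nitrogen; no ring) in place of a group of 7 heavy atoms (5 carbon, 2 nitrogen; no ring), on a saturated chain carbon bound to an amine nitrogen. The group that enters has 1 double bond outside aromatic rings and no ring, and it replaces 2-((3-aminopropyl)amino)ethyl on a saturated chain carbon bound to an amine nitrogen.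

Two measured steps offer guidance. For the measured compounds named here, the closer one is a 6.8-fold higher number from compound 1 to compound 2 (0.83 log units; beyond the scatter), which also changes the amine chain, but it is a much larger structural change than the one in compound 4. The other, a 15-fold lower number from compound 2 to compound 3 (1.19 log units; beyond the scatter), falls on the chain at the sulfonyl end, so it says little about this change. Going by the values given here, no measured compound carries a double bond, so that feature has no direct precedent here. A small move toward a lower number is expected, and it may stay within the scatter. The expected change is a 1.6-fold lower number from compound 2 to compound 4 (0.20 log units; within the scatter) in this series. Compound 4 is estimated at 3500 nM in this assay, with an expected range from 1200 nM to 9000 nM around that figure.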

Compound 4, half-maximal inhibitory concentration: 12700 nM
Compound 4: middle estimate off by 3.6-fold (0.56 log units), on the low side, and the stated range ends below it.
By their numbers in this assay, from the lowest: compound 3; then compound 1; then compound 2; then compound 4.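

In this assay, putting the group with 1 double bond in place of 2-((3-aminopropyl)amino)ethyl, on a saturated chain carbon bound to an amine nitrogen, gives a 2.3-fold higher number from compound 2 to compound 4 (0.36 log units; beyond the scatter) and so moves the number upward, a step that lies beyond the scatter. For the compounds shown here, the only earlier step on this amine chain, a 6.8-fold higher number from compound 1 to compound 2 (0.83 log units; beyond the scatter), showed compound 2 as the weaker member of that pair, so the two steps together show that changing the amine chain of compound 2 can shift the number in either direction: compound 1 stands lower than compound 2 and compound 4 stands higher. Nothing at hand accounts for this rise in the number.

The compounds shown leave open whether the double bond or the added carbon matters more here, a question that a saturated butane chain or an alkyne in the same place, with the rest of compound 4 kept, would address. They also leave open whether the dodecyl chain of compound 3 would lower the number of compound 4 as it does for compound 2.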